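A few compounds are considered here, and "the series" means these few. Any claim that something is new, unique, unknown or untested is made for them only; others in the source may bear on it.

Compound 1 `Clc1cccc(/N=N/N2CCCCC2)c1` gives in an ADME assay on MDBK cells (Bos taurus) for cytotoxicity, read by MTT assay, with a stated time of 96 h (on this read-out higher numbers stand for lower toxicity in this test and lower numbers for higher toxicity in this test), a value of > 100000 nM, which is a limit of the assay rather than a number.
Compound 2 `c1ccc(/N=N/N2CCCCC2)cc1` gives in this assay a value of > 100000 nM, again a limit of the assay.
Compound 3 `c1ccc(/N=N/N2CCCC2)cc1` gives in this assay a value of > 100000 nM, also a limit of the assay.

Compound 2 and compound 1 differ by chloro in place of hydrogen on an aromatic carbon. The step that the two limits leave unreadable from compound 2 to compound 1 cannot be sized, since the limit of > 100000 nM in this assay, at which 3 of the 3 values shown sit, places both compounds at the same limit. Compound 4 `Clc1ccc(/N=N/N2CCCC2)cc1` has not yet been measured; it differs from compound 3 by chloro in place of hydrogen on an aromatic carbon. Going by the values given here, this is the same kind of change as the one from compound 2 to compound 1, but not the same change: in compound 4 the chloro sits para to a group of 7 heavy atoms, in compound 1 meta to a group of 8 heavy atoms. How the core of compound 3 differs from the core of compound 2 is not broken down here. For compound 4 the expected step is a step that the limit leaves unreadable from compound 3 to compound 4, an expectation resting on (the limit of > 100000 nM in this assay, at which 3 of the 3 values shown sit), where every measured compound sits at the limit. Compound 4 is therefore estimated at 150000 nM, within 50000 nM to 500000 nM, most likely reported again only as a limit.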

Compound 4, half-maximal cytotoxic concentration: > 100000 nM
Compound 4: only a limit was reported; the forecaster's own chance of this, stated with the estimate: 85%; the middle value lies beyond the limit too.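

No step can be read from compound 3 to compound 4, since both give only a limit, which leaves the effect of chloro in place of hydrogen on an aromatic carbon unsized: the limit of > 100000 nM in this assay, at which 4 of the 4 values shown sit.

The compounds shown leave open whether chloro changes the result in this assay at all, and at what concentration any of these compounds becomes toxic to the cells.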